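Cytotoxicity notes: replacing the thiophene arm with a hydroxyphenyl amide

The compounds below may be only part of what the source reports. "The series", "measured", "known", "first", "only" and "open" are said of these compounds alone.

Two compounds of this series carry the same core and have been measured in a functional assay on RAW264.7 cells (Mus musculus) for cytotoxicity, read by MTT assay, with a stated time of 48 h, tested at 25 uM; on this read-out lower numbers stand for a weaker effect and higher numbers for a stronger effect at the one concentration tested. Compound 1 `CS(=O)(=O)c1ccc(Cc2nnc3n2N=C(c2cc(Cl)sc2S(N)(=O)=O)CS3)cc1` gives 18.7% in this assay. Compound 2 `CS(=O)(=O)c1ccc(Cc2nnc3n2N=C(c2cc4ccccc4c(=O)o2)CS3)cc1` gives 25.6% in this assay; the two numbers lie within the scatter of each other, so neither compound can be set above the other, and compound 1 simply stands at the lower of the two numbers.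

Compound 3 `CS(=O)(=O)c1ccc(Cc2nnc3n2N=C(c2ccc(O)c(C(N)=O)c2)CS3)cc1` has not yet been measured in this assay. It differs from compound 1 as follows: 3-carbamoyl-4-hydroxyphenyl in place of 5-chloro-2-sulfamoylthiophen-3-yl on a carbon with a double bond to nitrogen.

Among the measured compounds shown here, no step between measured compounds exists for this kind of change, so the expectation rests only on the two numbers so far. Both measured compounds sit low in this assay, and the step of a number 2.3 percentage points higher from compound 1 to compound 3 (within the scatter) is expected to be none beyond the scatter. Compound 3 is therefore estimated at 21%, with a range from 7% to 38% in this assay.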

Compound 3, a percentage reported as activity, at one concentration (the size of the read-out at that concentration, not a potency): 24.7%
Compound 3: the middle estimate sits 3.7 percentage points below what was measured, and the stated range covers the measured number.
By their numbers in this assay, from the lowest: compounds 1, 3 and 2 (each within the scatter of the next).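

In this assay, placing 3-carbamoyl-4-hydroxyphenyl in place of 5-chloro-2-sulfamoylthiophen-3-yl on the carbon with a double bond to nitrogen gives a number 6 percentage points higher from compound 1 to compound 3 (within the scatter), so this position takes a six-membered aromatic ring of carbon only as well as a five-membered aromatic ring with one hetero atom, with no difference that can be read. Within this single pair, the read-out does not depend on the chlorine or the sulfamoyl group being present at this position. Nothing at hand bears on why the two compounds read alike.

From the compounds shown here alone, it remains open whether the hydroxy group and the carbamoyl group matter separately on the phenyl ring, or whether a carboxylic acid in place of the carbamoyl group shifts the read-out. Equally open, going by these compounds, is whether an aminomethyl group or a longer chain at this position moves the number beyond the scatter.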